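Sulfanyl for sulfonyl on a chalcone-like chain: growth inhibition

The source may hold more compounds than are shown below. What is called first, only, known or untested is meant among the compounds shown, and "the series" means these compounds.

Measured compounds:
compound 1 `COc1ccc(/C=C(/Sc2ccc(C)cc2)C(=O)c2ccc(Cl)cc2)cc1O` gives 1000 nM
compound 2 `COc1ccc(/C=C(\C(=O)c2ccc(Cl)cc2)S(=O)(=O)c2ccc(C)cc2)cc1O` gives 1000 nM
compound 3 `Cc1ccc(S(=O)(=O)/C(=C/c2ccc(N(C)C)cc2)C(=O)c2ccc(Br)cc2)cc1` gives 50000 nM

All three were tested in a functional assay on DU-145 cells (Homo sapiens) for inhibition, read by trypan blue exclusion, with a stated time of 96 h; on this read-out lower numbers stand for stronger inhibition of growth and higher numbers for weaker inhibition of growth. Compound 1 and compound 2 share a core and differ in one place: (4-methylphenyl)sulfanyl in place of (4-methylphenyl)sulfonyl on a double-bonded chain carbon bound to a carbonyl carbon and a double-bonded chain carbon. That change made no change at the digits printed from compound 2 to compound 1 (within the scatter). Compound 3 stands apart, with a number well above those of compound 1 and compound 2; the difference between its core and the core of compound 2 is not broken down here.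

Compound 4 `Cc1ccc(S/C(=C/c2ccc(N(C)C)cc2)C(=O)c2ccc(Br)cc2)cc1` has not yet been tested in this assay. It is related to compound 3 by the same kind of change that links compound 2 to compound 1: (4-methylphenyl)sulfanyl in place of (4-methylphenyl)sulfonyl on a double-bonded chain carbon bound to a carbonyl carbon and a double-bonded chain carbon. Since that change left the number unchanged from compound 2 to compound 1, the expectation for compound 4 is also a step of about no change at the digits printed from compound 3 to compound 4 (within the scatter), which rests on compound 3 and its value 50000 nM. The estimate for compound 4 in this assay is therefore 50000 nM, expected to lie between 15000 nM and 150000 nM.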

Compound 4, concentration for 50% growth inhibition: > 100000 nM
Compound 4 gave a limit, no number (the forecaster's own chance of this, stated with the estimate: 20%); middle value at least 2.0-fold (0.30 log units) away from the limit.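

In this assay compound 4 gave > 100000 nM, which is a limit of the assay and not a number. From the compounds shown here alone, the change to (4-methylphenyl)sulfanyl on this second core can therefore be read only as a floor, and the true size of the step stays unknown: an at least 2.0-fold higher number from compound 3 to compound 4 (0.30 log units; that floor lies within the scatter). On neither core did the sulfanyl compound give a lower number than its sulfonyl partner, but this does not show whether the change carries over alike or acts differently from one core to the other: the same change on two cores in this assay, no change at the digits printed (within the scatter) from compound 2 to compound 1 and an at least 2.0-fold higher number (0.30 log units; that floor lies within the scatter) from compound 3 to compound 4; the limit leaves it open whether they differ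

The compounds shown leave open whether the same change would behave as it does here on a core carrying a carboxylic acid or a longer chain. They also leave open what an amide on the double-bonded chain carbon bound to a carbonyl carbon and a double-bonded chain carbon would do to growth inhibition in this assay.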